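Swapping a methoxy for a methyl in compound 3

A few compounds are considered here, and "the series" means these few. Any claim that something is new, unique, unknown or untested is made for them only; others in the source may bear on it.

In a physicochemical assay for acid dissociation, compound 2 (`COc1cnc(C[S+]([O-])c2nc3cc(OC(F)F)ccc3[nH]2)c(C)c1OC`) gives 3.73 and so sits level, within the scatter, with compound 1 (`COc1cnc(C[S+]([O-])c2nc3cc(OC(F)F)ccc3[nH]2)cc1OC`), which gives 3.75 on the same scale. Compound 3 (`COc1c(C)cnc(C[S+]([O-])c2nc3cc(OC(F)F)ccc3[nH]2)c1C`) has not yet been measured. It differs from compound 2 in one place: methyl in place of methoxy on an aromatic carbon that is, methyl in place of methoxy on an aromatic carbon, two atoms from the ring nitrogen of a six-membered aromatic ring with 1 nitrogen and para to a large group.

Among the measured compounds shown here, only one measured step bears on this change, methyl in place of hydrogen on an aromatic carbon, and it is not the same swap. For the measured compounds named here, no measured step shows what removing a methoxy does. With only a number 0.02 log units lower from compound 1 to compound 2 (within the scatter) to go on, a modest rise in this assay is expected, not clearly beyond the scatter, and its direction is a tentative call. The expected change is a number 0.27 log units higher from compound 2 to compound 3 (within the scatter) overall. For compound 3 the estimate is 4 with an expected range from 3.7 to 4.4 for the measurement.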

Compound 3, acid dissociation constant: 4.16
Compound 3: middle estimate off by 0.16 log units, on the low side, within the range that was stated.
By their numbers in this assay, from the lowest: compounds 2 and 1 (each within the scatter of the next); then compound 3.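

In this assay, putting methyl in place of methoxy on this aromatic carbon, two atoms from the ring nitrogen and para to a large group, gives a number 0.43 log units higher from compound 2 to compound 3 (beyond the scatter) and so produces the first step among these compounds that clears the usual noise of the measurement. The earlier step, a number 0.02 log units lower from compound 1 to compound 2 (within the scatter), came from a different change, methyl in place of hydrogen on an aromatic carbon, and left the two compounds level, so it gave no sign that a single swap on this ring could shift the number. This position therefore matters to the read-out, although no measurement shown here gives a reason for the rise.

Hydrogen on this carbon appears in none of the compounds shown, so it stays open whether the step comes from losing the methoxy or from gaining the methyl. From the compounds shown here alone, it is also open how an amine, a chlorine atom or a longer chain on this same carbon would move the number, or whether the same swap on another carbon of the ring would give a step of similar size.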